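Phenyl to thiophen-2-yl swap in an antiproliferative series

This account rests on a few compounds, and the source may have more. Where it says the series, first, only, none or still open, it means among the compounds named here.

Measured so far:
compound 1 `Nc1nc(N)c2c(-c3ccccc3)cn([C@@H]3O[C@H](CO)[C@@H](O)[C@H]3O)c2n1`: > 15000 nM
compound 2 `CNc1ncnc2c1c(-c1ccccc1)cn2[C@@H]1O[C@H](CO)[C@@H](O)[C@H]1O`: > 20000 nM
compound 3 `CNc1ncnc2c1c(-c1cccs1)cn2[C@@H]1O[C@H](CO)[C@@H](O)[C@H]1O`: > 20000 nM

In a functional assay on HL-60 cells (Homo sapiens) for antiproliferative activity, read by XTT assay, with a stated time of 72 h (a lower number here means a stronger inhibitor, a higher number a weaker inhibitor), compound 1 gives > 15000 nM, which is a limit of the assay and not a number. Compound 2 gives > 20000 nM, also a limit. Compound 3 gives > 20000 nM, again a limit. Compound 2 and compound 3 differ by thiophen-2-yl in place of phenyl on an aromatic carbon, and the step that the two limits leave unreadable from compound 2 to compound 3 cannot be sized because the limit of > 20000 nM in this assay, at which 2 of the 3 values shown sit, holds both readings. How the core of compound 1 differs from that of compound 2 is not broken down here.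

Compound 4 `Nc1nc(N)c2c(-c3cccs3)cn([C@@H]3O[C@H](CO)[C@@H](O)[C@H]3O)c2n1` differs from compound 1 by thiophen-2-yl in place of phenyl on an aromatic carbon, the same change as from compound 2 to compound 3. For compound 4 in this assay the expected step is a step that the limit leaves unreadable from compound 1 to compound 4, resting on the limit of > 15000 nM in this assay, at which 1 of the 3 values shown sits, for compound 1 and on the unreadable a step that the two limits leave unreadable from compound 2 to compound 3. Compound 4 is therefore estimated at 20000 nM, with a range from 8000 nM to 60000 nM, most likely reported only as a limit.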

Compound 4, half-maximal inhibitory concentration: > 20000 nM
Compound 4: a limit, no number (the forecaster's own chance of this, stated with the estimate: 85%); the middle value sits exactly at the limit.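

Within the data shown here, compound 1 and compound 4 both stand only as limits in this assay, and no step between them can be read. The compounds shown leave open how phenyl and thiophen-2-yl compare on either core, and whether any of them has a measurable potency in this assay.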